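Aryl triazole series: notes ahead of compound 4

The source may report more compounds than this note shows. Statements on the series, on what has been measured and on what is new or still open speak of the compounds shown alone.

In an ADME assay on HUVEC cells (Homo sapiens) for antiproliferative activity, read by MTT assay, with a stated time of 48 h (a lower number here means a stronger inhibitor, a higher number a weaker inhibitor), compound 1 `N#CC1=C(N)Oc2c(c3nc4ccccc4nc3c3ccccc23)C12C(=O)N(Cc1cnnn1-c1cccc(Br)c1)c1ccccc12` gives only a limit of the assay, > 50000 nM. Compound 2 `N#CC1=C(N)Oc2c(c3nc4ccccc4nc3c3ccccc23)C12C(=O)N(Cc1cnnn1-c1ccc([N+](=O)[O-])cc1)c1ccccc12` likewise gives only a limit, > 50000 nM. The step that the two limits leave unreadable from compound 1 to compound 2 is for that reason not readable. Compound 3 `N#CC1=C(N)Oc2c(N)cc3nc4ccccc4nc3c2C12C(=O)N(Cc1cnnn1-c1ccc(Cl)cc1)c1ccccc12` also returns only a limit, > 50000 nM. Among the measured compounds shown here, compound 3 thus stands where every value so far stands, at the limit of > 50000 nM in this assay, at which 3 of the 3 values shown sit. Compound 4 `COc1ccccc1-n1nncc1CN1C(=O)C2(C(C#N)=C(N)Oc3c(N)cc4nc5ccccc5nc4c32)c2ccccc21` differs from compound 3 by 2-methoxyphenyl in place of 4-chlorophenyl on an aromatic nitrogen. For the measured compounds named here, no readable step bears on this change, since the single recorded step is itself unreadable. With nothing to point the other way, the expected step that the limit leaves unreadable from compound 3 to compound 4 is none beyond the scatter. Compound 4 is therefore estimated at 80000 nM, within 30000 nM to 250000 nM, most likely reported again as a limit.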

Compound 4, half-maximal inhibitory concentration: > 50000 nM
Compound 4 was reported as a limit; the forecaster's own chance of this, stated with the estimate: 85%; the middle value does not contradict the limit.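

No step can be read from compound 3 to compound 4, since both values are limits: the limit of > 50000 nM in this assay, at which 4 of the 4 values shown sit.

The compounds shown leave open what any aryl change does in this assay, as no measured number exists to compare.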